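The compounds below may be only part of what the source reports. "The series", "measured", "known", "first", "only" and "open" are said of these compounds alone.

In a functional assay on A-431 cells (Homo sapiens) for inhibition, read by MTT assay, with a stated time of 72 h (a lower number here means a stronger inhibitor, a higher number a weaker inhibitor), three compounds built on one shared core have been measured. Compound 1 `C/C=C/C(=O)Nc1cccc(Oc2nc(Nc3cccc(OC)c3)nc3ccsc23)c1` gives 13100 nM. Compound 2 `CC/C=C/C(=O)Nc1cccc(Oc2nc(Nc3cccc(OC)c3)nc3ccsc23)c1` gives 29200 nM, and compound 3 `COc1cccc(Nc2nc(Oc3cccc(NC(=O)/C=C/C(C)C)c3)c3sccc3n2)c1` gives 23400 nM. Compound 2 thus holds the highest of the three numbers: the step of a 2.2-fold higher number from compound 1 to compound 2 (0.35 log units; beyond the scatter) lies beyond the usual scatter, whereas the step of a 1.2-fold lower number from compound 2 to compound 3 (0.10 log units; within the scatter) stays within it, so compound 2 and compound 3 cannot be told apart on these numbers.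

Compound 4 `CC/C=C/C(=O)Nc1cccc(Oc2nc(Nc3cccc(C#N)c3)nc3ccsc23)c1` differs from compound 2 in one place: cyano in place of methoxy on an aromatic carbon. Among the compounds with values here, all three measured steps concern the chain attached to the amide on the other side of the molecule, and none of them alters the ring that changes here, so no measured step bears directly on this change. With nothing to point either way, the expected outcome is a step no larger than the scatter, a 1.0-fold lower number from compound 2 to compound 4 (0.00 log units; within the scatter), in this assay. On that basis compound 4 is estimated at 29000 nM, with a range from 9000 nM to 90000 nM.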

Compound 4, half-maximal inhibitory concentration: 36200 nM
Compound 4: the middle estimate sits 1.2-fold (0.10 log units) below what was measured; low and high end bracket the measured number.
By their numbers in this assay, from the lowest: compounds 1, 3, 2 and 4 (each within the scatter of the next, the first and the last beyond it).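

In this assay, exchanging the 3-methoxyphenyl group for 3-cyanophenyl gives a 1.2-fold higher number from compound 2 to compound 4 (0.09 log units; within the scatter), so compound 2 and compound 4 cannot be told apart on these numbers. Within the data shown here, the earlier steps all concerned the chain on the amide, so this is the first reading from the other side of the molecule: with that chain held the same, methoxy and cyano at this position give no readable difference in this test. No measurement is available that would offer an explanation for this outcome.

One exchange cannot show whether this position is insensitive in general or whether these two groups merely happen to give similar numbers. A plain hydrogen, an amine or a carboxylic acid at the same place on this ring would test that further, and any of them could give a clearly different number.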